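Growth inhibition after a change on the amide nitrogen

The source may report more compounds than this note shows. Statements on the series, on what has been measured and on what is new or still open speak of the compounds shown alone.

Compounds measured in a functional assay on A549 cells (Homo sapiens) for inhibition, read by CCK-8 assay, with a stated time of 72 h, tested at 1 uM; a higher number here means more inhibition of growth at the concentration tested, a lower number less inhibition of growth:
Compound 1 `COC(=O)c1ccc(NC(=O)C2(C(=O)Nc3ccc(Nc4ncc5cc(C(=O)N(C)C)n(C6CCCC6)c5n4)cc3)CC2)cc1` gives 77.1%
Compound 2 `COc1ccc(NC(=O)C2(C(=O)Nc3ccc(Nc4ncc5cc(C(=O)N(C)C)n(C6CCCC6)c5n4)cc3)CC2)cc1` gives 74.4%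
Compound 3 `CN(C)C(=O)c1cc2cnc(Nc3ccc(NC(=O)C4(C(=O)Nc5ccc(Br)cc5)CC4)cc3)nc2n1C1CCCC1` gives -6.6%

Compound 3 stands lowest of the three at -6.6% in this assay. Compound 4 `CN(C)C(=O)c1cc2cnc(Nc3ccc(NC(=O)C4(C(=O)Nc5ccc(Cl)c(C(F)(F)F)c5)CC4)cc3)nc2n1C1CCCC1` differs from it at one place: 4-chloro-3-(trifluoromethyl)phenyl in place of 4-bromophenyl on an amide-type nitrogen. In words, 4-chloro-3-(trifluoromethyl)phenyl replaces 4-bromophenyl on an amide-type nitrogen. Two measured steps at this place bear on the change, a number 83.7 percentage points lower from compound 1 to compound 3 (beyond the scatter) and a number 81 percentage points lower from compound 2 to compound 3 (beyond the scatter), and both are large. By contrast, a number 2.7 percentage points lower from compound 1 to compound 2 (within the scatter) stays small. This place can therefore move the read-out far, but compound 4 keeps a halogen on the ring, as compound 3 does. Only a moderate rise is expected, with wide uncertainty. The expected step is a number 24.6 percentage points higher from compound 3 to compound 4 (beyond the scatter). The estimated value for compound 4 is 18%, with an expected range from -10% to 70%.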

Compound 4, percent growth inhibition at one concentration: 1.1%
Beside the measured number, compound 4's estimate is 16.9 percentage points above it; low and high end bracket the measured number.
By their numbers in this assay, from the lowest: compounds 3 and 4 (each within the scatter of the next); then compounds 2 and 1 (each within the scatter of the next).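

Replacing 4-bromophenyl with 4-chloro-3-(trifluoromethyl)phenyl gives a number 7.7 percentage points higher from compound 3 to compound 4 (within the scatter), so this second halogen-bearing ring stays within the scatter of compound 3. Against the other two rings, the same place gives a number 73.3 percentage points lower from compound 2 to compound 4 (beyond the scatter) and a number 76 percentage points lower from compound 1 to compound 4 (beyond the scatter), which sets the two halogen-bearing rings far under the 4-methoxyphenyl and 4-(methoxycarbonyl)phenyl rings, with no compound shown going against this split. No evidence at hand accounts for the split. As far as these compounds go, whether a lone chloro or lone trifluoromethyl group would fall with the low pair remains open. So does the place of an amine or a carboxylic acid on this ring.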